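Cytotoxicity notes: halogen swap on the pendant aryl ring

The source may hold more compounds than are shown below. What is called first, only, known or untested is meant among the compounds shown, and "the series" means these compounds.

Measured compounds:
- compound 1, `FC(F)(F)C(F)(F)C(F)(F)C(F)(F)C(F)(F)C(F)(F)CCn1cc(COc2ccccc2-c2nc3ccccc3s2)nn1`: 19800 nM
- compound 2, `Brc1ccc(-c2cc(COc3ccccc3-c3nc4ccccc4s3)on2)cc1`: 20000 nM
- compound 3, `c1ccc(-n2cc(COc3ccccc3-c3nc4ccccc4s3)nn2)cc1`: 26200 nM

All three were read in a functional assay on MCF7 cells (Homo sapiens) for cytotoxicity, read by MTT assay, with a stated time of 24 h; a higher number here means a weaker inhibitor, a lower number a stronger inhibitor. In this assay compound 2 gives 20000 nM, which sits second highest of the three numbers. Its nearest neighbour is compound 1 with 19800 nM, and the furthest is compound 3 with 26200 nM; both gaps fall within the scatter of repeated measurements, so the three compounds cannot be told apart on these data, and no ordering among them is claimed.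

The next compound in the series is compound 4, `Clc1ccc(-c2cc(COc3ccccc3-c3nc4ccccc4s3)on2)cc1`. It differs from compound 2 in one place only: chloro in place of bromo on an aromatic carbon, the site being on an aromatic carbon of a six-membered aromatic ring of carbon only, para to a large group. Among the compounds with values here, no pair of measured compounds differing in just this way is available, so there is no measured step to lean on.

Given that compound 2 shows 20000 nM and that the change is a single-atom halogen exchange, the step from compound 2 to compound 4 is expected to be small, no change at the digits printed from compound 2 to compound 4 (within the scatter), in no preferred direction and not beyond the scatter. Compound 4 is therefore estimated at 20000 nM, with a range of 9000 nM to 45000 nM.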

Compound 4, half-maximal inhibitory concentration: 23800 nM
Compound 4: the middle estimate sits 1.2-fold (0.08 log units) below what was measured; the range from low to high includes it.
By their numbers in this assay, from the lowest: compounds 1, 2, 4 and 3 (each within the scatter of the next).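

In this assay, within the data shown here, the exchange of 4-bromophenyl to 4-chlorophenyl gives a 1.2-fold higher number from compound 2 to compound 4 (0.08 log units; within the scatter), the first single-place step, and on this reading the two halogens cannot be told apart at this position. The step holds for this one pair of halogens on this one aromatic ring; compound 1 and compound 3 differ from compound 2 in more than one place, so it extends to neither of them. No measured evidence bears on why compound 2 and compound 4 read alike.

Going by these compounds, what a methoxy group, an amine or a carboxylic acid in place of the halogen would do in this assay stays open, as does whether this position responds to any change beyond the scatter. Also open, on these data alone, is how a plain phenyl without a halogen would compare with compound 2 and compound 4, and whether any change elsewhere on the shared core would separate compounds that so far lie within the scatter of one another.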